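The source may hold more compounds than are shown below. What is called first, only, known or untested is meant among the compounds shown, and "the series" means these compounds.

Three compounds have been measured in a functional assay on SW480 cells (Homo sapiens) for inhibition, read by luminescence and resazurin assay, with a stated time of 3 days; a lower number here means a stronger inhibitor, a higher number a weaker inhibitor:

compound 1, `O=C(Nc1ccc(F)cc1)c1ccc(CNc2nc(NC3CC3)nc3ccccc23)cc1`, gives 2600 nM
compound 2, `CCCNc1nc(NCc2ccc(C(=O)NC3CCN(Cc4ccc(F)cc4)CC3)cc2)c2cc(C)ccc2n1`, gives 1100 nM
compound 3, `CCCNc1nc(NCc2ccc(C(=O)NC3CCN(C(=O)c4ccc(F)cc4)CC3)cc2)c2cc(C)ccc2n1`, gives 5500 nM

Among these three, compound 3 gives the highest number, so it is the weakest inhibitor of the set; compound 1 comes nearest to it, and compound 2 lies furthest from it. Among the measured compounds shown here, the one single-point step among the measured compounds is the one in which the 4-fluorobenzyl on the ring amine nitrogen of compound 2 is exchanged for a (4-fluorophenyl)carbonyl, and it reads a 5.0-fold higher number from compound 2 to compound 3 (0.70 log units; beyond the scatter).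

Compound 4, `C=CCNc1nc(NCc2ccc(C(=O)NC3CCN(C(=O)c4ccc(F)cc4)CC3)cc2)c2cc(C)ccc2n1`, differs from compound 3 in one place: vinyl in place of ethyl on a saturated chain carbon bound to a nitrogen on an aromatic ring. For the measured compounds named here, no measured step touches this part of the molecule; the only step available concerns the group on the ring amine nitrogen at the far end of the structure, and it says nothing about the chain on the aromatic amine. With nothing to lean on, the expectation is that compound 4 stays close to compound 3, a step of no change at the digits printed from compound 3 to compound 4 (within the scatter), within the scatter. Compound 4 is therefore estimated at 5500 nM, with a range from 2500 nM to 12000 nM.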

Compound 4, half-maximal inhibitory concentration: 5200 nM
Compound 4: the middle estimate sits 1.1-fold (0.02 log units) above what was measured; measured number inside the range.
By their numbers in this assay, from the lowest: compound 2; then compounds 1, 4 and 3 (each within the scatter of the next, the first and the last beyond it).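

Within this assay the change from propylamino to allylamino, vinyl in place of ethyl on a saturated chain carbon bound to a nitrogen on an aromatic ring, gives a 1.1-fold lower number from compound 3 to compound 4 (0.02 log units; within the scatter) and is the first reading at this position. It shows that, on the background of compound 4, a double bond can enter this chain with no change beyond the scatter, while the count of heavy atoms stays the same. No supporting measurement is available to say why the two chains read alike.

The compounds shown do not tell whether a longer chain such as butyl, or a chain ending in an amine or a hydroxyl group, would read the same here. As far as these compounds go, it also stays open whether this exchange would read the same with the 4-fluorobenzyl of compound 2 on the ring amine nitrogen.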